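Swapping a Fluoro for a Chloro on the Hydrazone Ring

The compounds below may be only part of what the source reports. "The series", "measured", "known", "first", "only" and "open" are said of these compounds alone.

Compound 2 `CN(C)CCn1cnnc1-c1cc(Oc2ccc(NC(=O)N/N=C/c3ccc(F)cc3F)cc2F)ccn1` is a urea whose hydrazone bears a 2,4-difluorophenyl group. Going by the values given here, in a functional assay on NCI-H460 cells (Homo sapiens) for cytotoxicity, read by MTT assay, with a stated time of 72 h (a higher number here means a weaker inhibitor, a lower number a stronger inhibitor), compound 2 gives 1930 nM, the lowest of the two numbers known; the only other measured compound, compound 1 `Cn1ncnc1-c1cc(Oc2ccc(NC(=O)N/N=C/c3ccccc3)cc2F)ccn1`, gives 52200 nM in this assay, a gap that lies beyond the scatter. Compound 3 `CN(C)CCn1cnnc1-c1cc(Oc2ccc(NC(=O)N/N=C/c3ccc(F)cc3Cl)cc2F)ccn1` differs from compound 2 only in that (chloro in place of fluoro on an aromatic carbon). Among the compounds with values here, with no comparable step measured, a small change is expected, a 1.0-fold lower number from compound 2 to compound 3 (0.01 log units; within the scatter), within the scatter. Compound 3 is therefore estimated at 1900 nM, between 700 nM and 5200 nM.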

Compound 3, half-maximal inhibitory concentration: 720 nM
For compound 3 the middle estimate is 2.6-fold (0.42 log units) above the measured one; low and high end bracket the measured number.
By their numbers in this assay, from the lowest: compound 3; then compound 2; then compound 1.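

On the ring carbon ortho to a large group, a single-atom swap is enough to move the result. In this assay chloro in place of fluoro gives a 2.7-fold lower number from compound 2 to compound 3 (0.43 log units; beyond the scatter) and so counts as a modest but real change. Going from 2,4-difluorophenyl to 2-chloro-4-fluorophenyl adds no ring and no hydrogen-bond donors or acceptors, and nothing measured here accounts for the shift.

As far as these compounds go, whether bromo, methyl or an amine on this carbon would lower the number further stays open. So does the effect of chloro in place of the other fluoro on this ring.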